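Exchanging one aromatic group on compound 3

A few compounds are considered here, and "the series" means these few. Any claim that something is new, unique, unknown or untested is made for them only; others in the source may bear on it.

For the measured compounds named here, in a physicochemical assay for solubility (on this read-out lower numbers stand for lower solubility and higher numbers for higher solubility), compound 3 `Cc1ccc(-c2cc(C(F)(F)F)ccc2[C@H]2CCOc3cc(S(=O)(=O)Nc4ccncn4)ccc32)cn1` gives 181000 nM and stands second highest of the three numbers known so far. Compound 4 `Cn1nccc1-c1cc(C(F)(F)F)ccc1[C@H]1CCOc2cc(S(=O)(=O)Nc3ccncn3)ccc21` has 1-methyl-1H-pyrazol-5-yl in place of 6-methylpyridin-3-yl on an aromatic carbon and has not yet been measured. Going by the values given here, no measured step covers this exchange. Among the compounds with values here, the one available step a 14-fold higher number from compound 1 to compound 2 (1.15 log units; beyond the scatter) concerns the group on a sulfonamide nitrogen instead, so it shows only how far this assay can move. Compound 1 `Cn1nccc1-c1cc(C(F)(F)F)ccc1[C@H]1CCOc2cc(S(=O)(=O)Nc3nccs3)ccc21` at 83000 nM and compound 2 `Cn1nccc1-c1cc(C(F)(F)F)ccc1[C@H]1CCOc2cc(S(=O)(=O)Nc3cnccn3)ccc21` at 1170000 nM already carry 1-methyl-1H-pyrazol-5-yl and lie on either side of compound 3, so a modest upward step is expected. The estimated step of a 1.7-fold higher number from compound 3 to compound 4 (0.22 log units; within the scatter) is small compared with the measured one. Compound 4 is expected at 300000 nM with 110000 nM to 800000 nM as the estimated range.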

Compound 4, solubility: 1180000 nM
Beside the measured number, compound 4's estimate is 3.9-fold (0.59 log units) below it; measured number above the stated range.
By their numbers in this assay, from the lowest: compound 1; then compound 3; then compounds 2 and 4 (each within the scatter of the next).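

The aromatic carbon ortho to a large group matters in this assay: 1-methyl-1H-pyrazol-5-yl in place of 6-methylpyridin-3-yl gives the first step read at this position (a 6.5-fold higher number from compound 3 to compound 4 (0.81 log units; beyond the scatter)). With 1-methyl-1H-pyrazol-5-yl held in place, pyrimidin-4-yl and pyrazin-2-yl on the sulfonamide nitrogen cannot be told apart (a 1.0-fold higher number from compound 2 to compound 4 (0.00 log units; within the scatter)), whereas the 1,3-thiazol-2-yl group stands apart (a 14-fold higher number from compound 1 to compound 4 (1.15 log units; beyond the scatter)). No measurement at hand explains these steps. Still open, going by these compounds, is how an amine or a carboxylic acid on that aromatic carbon would read, and whether this exchange gives a similar step with another group on the sulfonamide nitrogen.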